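Series notes: methoxy added, compound 3 to compound 4

A few compounds are considered here, and "the series" means these few. Any claim that something is new, unique, unknown or untested is made for them only; others in the source may bear on it.

Compound 3 `CN(c1cccc2c1CN(c1nc(Nc3cccc(C(F)(F)F)c3)ncc1C(F)(F)F)C2)S(C)(=O)=O` carries 3-(trifluoromethyl)phenyl on a nitrogen of the shared core. In a functional assay on U-87MG ATCC cells for antiproliferative activity against U-87 MG (Homo sapiens), read by spectrophotometry, with a stated time of 2 days (a higher number here means a weaker inhibitor of growth, a lower number a stronger inhibitor of growth), compound 3 reaches only the limit > 30000 nM. Compound 1 `COc1ccc(Nc2ncc(C(F)(F)F)c(N3Cc4cccc(N(C)S(C)(=O)=O)c4C3)n2)cc1C(F)(F)F` gives 29400 nM in this assay, and compound 2 `Cc1cc(Cl)ccc1Nc1ncc(C(F)(F)F)c(N2Cc3cccc(N(C)S(C)(=O)=O)c3C2)n1` gives 28300 nM. Because compound 3 sits at the limit of > 30000 nM in this assay, at which 1 of the 3 values shown sits, the steps of an at least 1.0-fold higher number from compound 1 to compound 3 (0.00 log units; that floor lies within the scatter) and an at least 1.0-fold higher number from compound 2 to compound 3 (0.02 log units; that floor lies within the scatter) are floors only; a 1.0-fold lower number from compound 1 to compound 2 (0.02 log units; within the scatter) completes the picture. Compound 4 `COc1cc(Nc2ncc(C(F)(F)F)c(N3Cc4cccc(N(C)S(C)(=O)=O)c4C3)n2)cc(C(F)(F)F)c1` differs from compound 3 by methoxy in place of hydrogen on an aromatic carbon. Going by the values given here, the one step that bears on this, an at least 1.0-fold higher number from compound 1 to compound 3 (0.00 log units; that floor lies within the scatter), is the reverse change and stayed within the scatter. For compound 4 the expected step that the limit leaves unreadable from compound 3 to compound 4 is therefore none beyond the scatter, with a real chance of another limit. Compound 4 is estimated at 35000 nM, range 15000 nM to 90000 nM.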

Compound 4, concentration for 50% growth inhibition: > 30000 nM
Compound 4 gave a limit, no number (the forecaster's own chance of this, stated with the estimate: 60%); the middle value does not contradict the limit.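

With methoxy on the aromatic carbon meta to the trifluoromethyl group, compound 4 also stays at a limit in this assay, so 3-methoxy-5-(trifluoromethyl)phenyl shows no readable gain over 3-(trifluoromethyl)phenyl: the limit of > 30000 nM in this assay, at which 2 of the 4 values shown sit. The step for the methoxy change itself cannot be read. The readable floors, an at least 1.0-fold higher number from compound 2 to compound 4 (0.02 log units; that floor lies within the scatter) and an at least 1.0-fold higher number from compound 1 to compound 4 (0.00 log units; that floor lies within the scatter), separate compound 4 from neither compound.

On these data alone, how far compound 3 and compound 4 lie past the limit stays open. Also open, as far as these compounds go, is whether an amine or a carboxylic acid at this position would give a readable number.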